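This account rests on a few compounds, and the source may have more. Where it says the series, first, only, none or still open, it means among the compounds named here.

Measured compounds in a functional assay on UO-31 cells (Homo sapiens) for inhibition, read by sulforhodamine B assay, tested at 10 uM; on this read-out lower numbers stand for less inhibition and higher numbers for more inhibition at the one concentration tested (going by the name of the read-out):
- compound 1 `COc1cc2oc(-c3cccc(NC(=O)c4ccc(C)cc4)c3)cc(=O)c2c(OC)c1OC` — "active" (no number reported)
- compound 2 `COc1cc2oc(-c3cccc(NC(=O)c4ccc(Br)cc4)c3)cc(=O)c2c(OC)c1OC` — 63.6%
- compound 3 `COc1cc2oc(-c3cccc(NC(=O)c4ccc(C#N)cc4)c3)cc(=O)c2c(OC)c1OC` — "active" (no number reported)

All three share one core and differ only in the group on the benzamide ring. Among the compounds with values here, compound 2 is the only one with a single number in this assay, where compound 2 gives 63.6%. Compound 3 stands without a single number in this assay; its result is given only as a reported verdict, reported as active, and compound 1 is in the same position, so no ranking of compound 3 against compound 1 or compound 2 can be drawn from what is shown, and nothing is known about how any of them bind.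

The next compound is compound 4 `COc1cc2oc(-c3cccc(NC(=O)c4ccc([N+](=O)[O-])cc4)c3)cc(=O)c2c(OC)c1OC`. It differs from compound 3 in one place: nitro in place of cyano on an aromatic carbon. The change keeps the group on the same aromatic carbon, para to a large group, and only swaps cyano for nitro.

Within the data shown here, no step between measured compounds is available that would calibrate this swap, so the size of the step from compound 3 to compound 4 in this assay is taken as none beyond the scatter, in either direction. Compound 4 is therefore estimated to land near the one number shown in the series, at 60% with an expected range of 35% to 85%.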

Compound 4, a percentage reported as inhibition, at one concentration (the size of the read-out at that concentration, not a potency): "active" (no number reported)
Nothing numeric was reported for compound 4, so the estimate cannot be set against anything.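

In this assay, within the data shown here, compound 3 and compound 4 both stand as verdicts without a number, so no step from cyano to nitro can be read, and no evidence bears on either result.

As far as these compounds go, how compound 1, compound 3 and compound 4 would rank numerically against compound 2 remains open.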